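Benzylamine variation on a bis(trifluoromethyl)benzenesulfonamide chain

The source may report more compounds than this note shows. Statements on the series, on what has been measured and on what is new or still open speak of the compounds shown alone.

Measured so far in a functional assay on MCF7 cells (Homo sapiens) for inhibition, read by MTT assay, with a stated time of 72 h; a higher number here means a weaker inhibitor of growth, a lower number a stronger inhibitor of growth:
- compound 1 `O=S(=O)(NCCCNCc1ccccc1Cl)c1cc(C(F)(F)F)cc(C(F)(F)F)c1`: 8800 nM
- compound 2 `O=S(=O)(NCCCNCc1ccc(Cl)c(C(F)(F)F)c1)c1cc(C(F)(F)F)cc(C(F)(F)F)c1`: 3500 nM
- compound 3 `COc1ccc(CNCCCNS(=O)(=O)c2cc(C(F)(F)F)cc(C(F)(F)F)c2)cc1`: 2500 nM

Compound 3 gives the lowest number of the three in this assay. Its separation from compound 2 is a 1.4-fold lower number from compound 2 to compound 3 (0.15 log units; within the scatter), which does not rank the two; its separation from compound 1 is a 3.5-fold lower number from compound 1 to compound 3 (0.55 log units; beyond the scatter), a real gap. The remaining measured step, a 2.5-fold lower number from compound 1 to compound 2 (0.40 log units; beyond the scatter), also moves away from the 2-chlorophenyl member.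

Compound 4 `O=S(=O)(NCCCNCc1cccc(Cl)c1)c1cc(C(F)(F)F)cc(C(F)(F)F)c1` carries the change (3-chlorophenyl in place of 4-methoxyphenyl on a saturated chain carbon bound to an amine nitrogen). Among the compounds with values here, no measured step covers this exact exchange. What the numbers do show is that both chlorine-bearing benzyl groups sat at higher numbers than compound 3, by a modest margin for compound 2 and a larger one for compound 1. A 3-chlorophenyl member is therefore expected to land between those two, giving an estimated step of a 1.8-fold higher number from compound 3 to compound 4 (0.26 log units; within the scatter). The expected value for compound 4 in this assay is 4500 nM, with a range from 2000 nM to 10000 nM, the range acknowledging that the chlorine position has not been probed directly.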

Compound 4, concentration for 50% growth inhibition: 2600 nM
Estimate against measurement, compound 4: 1.7-fold (0.24 log units) above; the range from low to high includes it.
By their numbers in this assay, from the lowest: compounds 3, 4 and 2 (each within the scatter of the next); then compound 1.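

In this assay the 3-chlorophenyl group cannot be told apart from the 4-methoxyphenyl group (a 1.0-fold higher number from compound 3 to compound 4 (0.02 log units; within the scatter)) or from the 4-chloro-3-(trifluoromethyl)phenyl group (a 1.3-fold lower number from compound 2 to compound 4 (0.13 log units; within the scatter)), so among these compounds a chlorine on the benzyl ring does not by itself go with a higher number. Compound 1 goes against that reading, and the step that keeps the chlorine and changes only its place, 3-chlorophenyl in place of 2-chlorophenyl, is beyond the scatter (a 3.4-fold lower number from compound 1 to compound 4 (0.53 log units; beyond the scatter)). No measured evidence on this series accounts for these numbers.

Still open, from the compounds shown here alone, is how 4-chlorophenyl and 2-methoxyphenyl groups would read at this place, which would show whether the 2-chlorophenyl result is specific to chlorine. Going by these compounds, a longer chain on the sulfonamide nitrogen is also open.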